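The compounds below may be only part of what the source reports. "The series", "measured", "known", "first", "only" and "open" are said of these compounds alone.

Compound 1 `CCOS(=O)(=O)c1ccc(F)c2ncc(I)cc12` and compound 2 `CC(C)OS(=O)(=O)c1ccc(F)c2ncc(I)cc12` share one core and differ only in the ester chain. In an assay for inhibition of methylcytosine dioxygenase TET2 (Homo sapiens), read by mass spectrometry, with stated times of 30 min and 1 h (a lower number here means a stronger inhibitor, a higher number a weaker inhibitor), compound 1 reaches only the limit > 200000 nM. In this assay compound 2 likewise stands at the limit > 200000 nM. The step that the two limits leave unreadable from compound 1 to compound 2 therefore has no readable size because both values rest on (the limit of > 200000 nM in this assay, at which 2 of the 2 values shown sit). Compound 3 `Nc1cccc(OS(=O)(=O)c2ccc(F)c3ncc(I)cc23)c1` differs from compound 2 by 3-aminophenyl in place of isopropyl on an oxygen. Among the measured compounds shown here, no measured step bears on this change, and compound 2 itself offers only a limit. The step of a number no higher from compound 2 to compound 3 (the limit leaves the size open) is expected to stay within the unreadable range. Compound 3 is estimated at 200000 nM, in the range 50000 nM to 800000 nM, most likely again reported only as a limit.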

Compound 3, half-maximal inhibitory concentration: > 200000 nM
Compound 3 was reported as a limit (the forecaster's own chance of this, stated with the estimate: 80%); the middle value sits exactly at the limit.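

Among the compounds shown here, no step among compound 1, compound 2 and compound 3 can be read, because all three stand only at a limit: the limit of > 200000 nM in this assay, at which 3 of the 3 values shown sit. Going by these compounds, whether any group on this oxygen gives a measurable value in this assay stays open.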